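The source may report more compounds than this note shows. Statements on the series, on what has been measured and on what is new or still open speak of the compounds shown alone.

Measured so far in a functional assay on NCI-H1975 cells (Homo sapiens) for cytotoxicity, read by MTT assay, with a stated time of 72 h; a lower number here means a stronger inhibitor, a higher number a weaker inhibitor:
- compound 1 `CC(C)n1c(Nc2ccccc2)nc2cnc(Nc3ccc(N4CCN(C)CC4)cc3)nc21`: 960 nM
- compound 2 `CC(=O)Nc1ccc(Nc2ncc3nc(Nc4ccccc4)n(C4CCCC4)c3n2)cc1`: 1210 nM
- compound 3 `C#Cc1cccc(Nc2nc3cnc(Nc4ccc(N5CCN(C)CC5)cc4)nc3n2C2CCCC2)c1`: 650 nM

Compound 3, at 650 nM, stands within the usual scatter of both compound 1 and compound 2, so these numbers do not separate it from either one. Compound 4 `CN1CCN(c2ccc(Nc3ncc4nc(Nc5cccc(Cl)c5)n(C5CCCC5)c4n3)cc2)CC1` keeps the rest of compound 3 but has chloro in place of ethynyl on an aromatic carbon, which turns 3-ethynylphenyl into 3-chlorophenyl (chloro in place of ethynyl on an aromatic carbon). Within the data shown here, no two measured compounds differ in only one place, so the data give no direct guide to this swap. A step of a 1.1-fold higher number from compound 3 to compound 4 (0.03 log units; within the scatter) is expected, and it is not expected to go beyond the scatter in this assay. The estimate for compound 4 is 700 nM, with an expected range of 280 nM to 1700 nM.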

Compound 4, half-maximal inhibitory concentration: 390 nM
Compound 4: middle estimate off by 1.8-fold (0.25 log units), on the high side; low and high end bracket the measured number.
By their numbers in this assay, from the lowest: compounds 4, 3, 1 and 2 (each within the scatter of the next, the first and the last beyond it).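

In this assay, among these compounds, exchanging ethynyl for chloro, which turns 3-ethynylphenyl into 3-chlorophenyl, gives a 1.7-fold lower number from compound 3 to compound 4 (0.22 log units; within the scatter) and is the first one-place comparison in this set. At this position, these numbers do not separate the two-carbon ethynyl group from the single chlorine atom. Nothing measured here offers an explanation for this result. As far as these compounds go, whether the same holds for very different groups at this position, such as an amine or a carboxylic acid, remains open. So does the effect of chloro on other carbons of this ring.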